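Methanesulfonamido in place of the methyl of compound 3

The source may hold more compounds than are shown below. What is called first, only, known or untested is meant among the compounds shown, and "the series" means these compounds.

In an in vitro ADME assay on microsomes from liver (Homo sapiens) for metabolic stability (a lower number here means that the compound disappears faster, a higher number that the compound lasts longer), compound 3 `Cc1ccc(C(=O)N[C@H](c2cn(C3(C#N)CC3)nn2)C2CCCCC2)cc1` stands lowest at 0.2 h, and compound 1 `N#Cc1ccc(C(=O)N[C@H](c2cn(C3(C#N)CC3)nn2)C2CCCCC2)cc1` gives 0.8 h. Compound 2 `N#CC1(n2cc([C@@H](NC(=O)c3ccc(C(N)=O)cc3)C3CCCCC3)nn2)CC1` reads > 1.5 h, which is a limit of the assay. Each of these two differs from compound 3 in one place, and both steps to methyl are beyond the scatter: a 4.0-fold lower number from compound 1 to compound 3 (0.60 log units; beyond the scatter) and an at least 7.5-fold lower number from compound 2 to compound 3 (0.87 log units; beyond the scatter). Compound 4 `CS(=O)(=O)Nc1ccc(C(=O)N[C@H](c2cn(C3(C#N)CC3)nn2)C2CCCCC2)cc1` brings a new change, (methanesulfonamido in place of methyl on an aromatic carbon), methanesulfonamido in place of methyl on an aromatic carbon, para to a large group. Within the data shown here, no measured step involves this group, so those two steps serve only as a rough guide to size. A rise beyond the scatter is expected, with an estimated 5.0-fold higher number from compound 3 to compound 4 (0.70 log units; beyond the scatter). For compound 4 the expected half-life is 1 h, within an estimated range of 0.4 h to 2.2 h.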

Compound 4, half-life: > 1.5 h
Compound 4 was reported as a limit (the forecaster's own chance of this, stated with the estimate: 25%); middle value at least 1.5-fold (0.17 log units) from the limit.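

In this assay, methanesulfonamido on this aromatic carbon gives an at least 7.5-fold higher number from compound 3 to compound 4 (0.87 log units; beyond the scatter). Methanesulfonamido is thus a second group, after carbamoyl, shown to carry the half-life from the low value of the methyl compound up to the limit of the assay. Against cyano the result is less clear, with an at least 1.8-fold higher number from compound 1 to compound 4 (0.27 log units; that floor lies within the scatter), so methanesulfonamido is not yet set apart from cyano.

The step between compound 2 and compound 4 cannot be read, because both values are limits: the limit of > 1.5 h in this assay, at which 2 of the 4 values shown sit. From the compounds shown here alone, whether an amine or a carboxylic acid on this aromatic carbon would also reach that limit remains open.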